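The source may report more compounds than this note shows. Statements on the series, on what has been measured and on what is new or still open speak of the compounds shown alone.

Measured compounds in an assay on isolated protein for inhibition of cathepsin S (Homo sapiens); on this read-out higher numbers stand for weaker binding and lower numbers for tighter binding:
- Compound 1, `N#C[C@@]1(NC(=O)[C@@H](CC(=O)N2CCOCC2)CC2CCCCC2)CCNC1`: 123 nM
- Compound 2, `CN1CC[C@@](C#N)(NC(=O)[C@@H](CC(=O)N2CCOCC2)CC2CCCCC2)C1`: 161 nM

Compound 2 differs from compound 1 only by a methyl in place of hydrogen on an amine nitrogen in a ring, and the step of a 1.3-fold higher number from compound 1 to compound 2 (0.12 log units; within the scatter) shows that the two numbers cannot be told apart; compound 2 therefore stands next to compound 1 rather than apart from it.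

Compound 3, `CC(C)N1CC[C@@](C#N)(NC(=O)[C@@H](CC(=O)N2CCOCC2)CC2CCCCC2)C1`, has not yet been measured in this assay. It differs from compound 2 by isopropyl in place of methyl on an amine nitrogen in a ring. Among the compounds with values here, the only measured step that bears on this change is the one from compound 1 to compound 2, where the same nitrogen was changed from hydrogen to methyl, and that step stayed within the scatter. Growing the methyl to isopropyl is a further change in the same place, but there is no measured step for this particular group, so the direction is uncertain.

On this basis a step of about a 1.2-fold higher number from compound 2 to compound 3 (0.09 log units; within the scatter) is expected, which is no step beyond the scatter; compound 3 is estimated at 200 nM, between 90 nM and 450 nM.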

Compound 3, dissociation constant: 60.6 nM
The estimate for compound 3 lay 3.3-fold (0.52 log units) above the measured number, outside the stated range (below it).
By their numbers in this assay, from the lowest: compound 3; then compounds 1 and 2 (each within the scatter of the next).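

In this assay, the amine nitrogen in the five-membered ring had looked indifferent to substitution, since hydrogen to methyl gave only a 1.3-fold higher number from compound 1 to compound 2 (0.12 log units; within the scatter); isopropyl shows that this position can still move the number. Isopropyl in place of methyl gives a 2.7-fold lower number from compound 2 to compound 3 (0.42 log units; beyond the scatter), and isopropyl in place of hydrogen gives a 2.0-fold lower number from compound 1 to compound 3 (0.31 log units; beyond the scatter), so both steps lie beyond the scatter, and the larger group on this nitrogen goes with tighter binding than either smaller one, though both steps are modest. Nothing available explains why isopropyl differs from methyl and hydrogen here, while these two cannot be told apart.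

The three compounds leave open whether the number depends on the size of the group, on its branching or on both, which ethyl, n-propyl, tert-butyl or cyclopropyl on the same nitrogen would help to separate. They also leave open whether a longer chain or a benzyl group would take the number lower still, and whether isopropyl would give a similar step on another core.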